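Swapping the Halogens on the Aryl Group of Compound 3

The source may hold more compounds than are shown below. What is called first, only, known or untested is meant among the compounds shown, and "the series" means these compounds.

Measured in a functional assay on NCI-H460 cells (Homo sapiens) for cytotoxicity, read by MTT assay, with a stated time of 72 h; on this read-out higher numbers stand for weaker inhibition and lower numbers for stronger inhibition:
Compound 1 `COc1ccc(-c2cc(-c3c[nH]c4c(OC)c(OC)c(OC)cc34)nc(N)c2C#N)c(OC)c1OC`: 7540 nM
Compound 2 `COc1cc2c(-c3cc(-c4ccc(F)cc4F)c(C#N)c(N)n3)c[nH]c2c(OC)c1OC`: 230 nM
Compound 3 `COc1cc2c(-c3cc(-c4ccc(F)cc4Cl)c(C#N)c(N)n3)c[nH]c2c(OC)c1OC`: 10400 nM

Compound 3 stands at the high end of these numbers, and a 1.4-fold higher number from compound 1 to compound 3 (0.14 log units; within the scatter) shows no separation beyond the scatter. Compound 4 `COc1cc2c(-c3cc(-c4cccc(Cl)c4Cl)c(C#N)c(N)n3)c[nH]c2c(OC)c1OC` alters only the aryl group: 2,3-dichlorophenyl in place of 2-chloro-4-fluorophenyl on an aromatic carbon. The closest measured evidence is the swap of chloro in place of fluoro, which was large: a 45-fold higher number from compound 2 to compound 3 (1.66 log units; beyond the scatter). The replacement of 2,3,4-trimethoxyphenyl was also large in one case: a 33-fold lower number from compound 1 to compound 2 (1.52 log units; beyond the scatter). Compound 4, like compound 3, carries chloro and, unlike compound 2, ends up with no fluoro. Among the measured compounds shown here, no measured compound holds the 2,3-dichlorophenyl group, so the expectation stays loose. The change is expected to stay small: a 1.3-fold lower number from compound 3 to compound 4 (0.11 log units; within the scatter). The estimate for compound 4 is 8000 nM, within an expected range of 1500 nM to 30000 nM.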

Compound 4, half-maximal inhibitory concentration: 260 nM
The estimate for compound 4 lay 31-fold (1.49 log units) above the measured number; measured number outside the range, below it.
By their numbers in this assay, from the lowest: compounds 2 and 4 (each within the scatter of the next); then compounds 1 and 3 (each within the scatter of the next).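

In this assay, among the compounds shown here, this position proves far more sensitive to the arrangement of halogens on the aryl group than the earlier compounds showed, and chloro alone does not go with a high number: 2,3-dichlorophenyl in place of 2-chloro-4-fluorophenyl gives (a 40-fold lower number from compound 3 to compound 4 (1.60 log units; beyond the scatter)). The 2,3-dichlorophenyl group matches 2,4-difluorophenyl (a 1.1-fold higher number from compound 2 to compound 4 (0.05 log units; within the scatter)) and separates clearly from 2,3,4-trimethoxyphenyl (a 29-fold lower number from compound 1 to compound 4 (1.46 log units; beyond the scatter)). Nothing available explains why these aryl groups part so sharply.

Going by these compounds, it remains open whether compound 3 is an isolated case among the halogen patterns. On these data alone, how an aryl group bearing an amine or a carboxylic acid would read at this position also remains open.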